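The compounds below may be only part of what the source reports. "The series", "measured", "known", "first", "only" and "open" are said of these compounds alone.

Working notes on a series of pyrazole hydrazides measured in a physicochemical assay for lipophilicity; on this read-out higher numbers stand for higher lipophilicity and lower numbers for lower lipophilicity.

Compound 1 `NNC(=O)c1cc(-c2ccccc2)nn1Cc1ccccc1` gives 2.73 in this assay. Compound 2 `NNC(=O)c1cc(-c2ccccc2)nn1Cc1ccc(Cl)nc1` carries 6-chloropyridin-3-yl in place of phenyl on a saturated chain carbon bound to an aromatic nitrogen and gives 2.52; the step of a number 0.21 log units lower from compound 1 to compound 2 (within the scatter). Compound 3 `COc1ccc(-c2cc(C(=O)NN)n(Cc3ccccc3)n2)cc1` differs from compound 1 by methoxy in place of hydrogen on an aromatic carbon; in this assay compound 3 gives 2.87; the step of a number 0.14 log units higher from compound 1 to compound 3 (within the scatter). Compound 3 and compound 2 stand further apart, their values showing a gap that lies beyond the scatter.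

Compound 4 `COc1ccc(-c2cc(C(=O)NN)n(Cc3ccc(Cl)nc3)n2)cc1` has not yet been measured in this assay. It differs from compound 3 by 6-chloropyridin-3-yl in place of phenyl on a saturated chain carbon bound to an aromatic nitrogen, the same change already seen from compound 1 to compound 2, at the same place on the core. Going by the values given here, the only reference for the size of this change is the single pair where it was measured, so the expectation rests on that one step and on the core difference being read as small. The step is expected to be a number 0.21 log units lower from compound 3 to compound 4 (within the scatter), close to the earlier a number 0.21 log units lower from compound 1 to compound 2 (within the scatter). Compound 4 is therefore estimated at 2.66, with a range from 2.4 to 2.92.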

Compound 4, partition coefficient: 2.76
Compound 4: middle estimate off by 0.10 log units, on the low side, and the stated range covers the measured number.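

In this assay the exchange of phenyl for 6-chloropyridin-3-yl reads as a number 0.11 log units lower from compound 3 to compound 4 (within the scatter) on the core bearing methoxy and as a number 0.21 log units lower from compound 1 to compound 2 (within the scatter) on the core of compound 1, while methoxy in place of hydrogen reads as a number 0.24 log units higher from compound 2 to compound 4 (within the scatter) with 6-chloropyridin-3-yl present and as a number 0.14 log units higher from compound 1 to compound 3 (within the scatter) with phenyl present. All four steps lie within the scatter, so the exchange carries across these two cores without any step standing clear of repeat variation, but this single pair of cores cannot show that the exchange has a real effect, or whether its size holds from one core to the other. Nothing measured here offers an explanation for these numbers.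

The compounds shown leave open whether the same reading would hold on a third core. They also leave open what a carboxylic acid, an amine such as morpholine or a longer chain than benzyl would give on that saturated chain carbon.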